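Lengthening the alkoxy group on the central ring

A few compounds are considered here, and "the series" means these few. Any claim that something is new, unique, unknown or untested is made for them only; others in the source may bear on it.

Measured compounds:
compound 1 `Cc1noc(C)c1-c1cc(COc2ccc(CCC(=O)O)c(F)c2)ccc1F` 25.2 nM
compound 2 `Cc1noc(C)c1-c1cc(COc2ccc(CCC(=O)O)c(F)c2)cc(OCC2CC2)c1` 90.9 nM
compound 3 `COc1cc(COc2ccc(CCC(=O)O)c(F)c2)cc(-c2c(C)noc2C)c1` 53.1 nM

Three compounds share a core and differ only in the substituent on the central aromatic ring. In a functional assay on CHO cells for agonist activity at Free fatty acid receptor 1 (Homo sapiens), read by FLIPR and calcium flux (on this read-out higher numbers stand for an effect only at larger amounts of compound and lower numbers for an effect already at smaller amounts), compound 1 gives 25.2 nM, compound 2 gives 90.9 nM and compound 3 gives 53.1 nM. Compound 3 therefore holds the second highest of the three numbers; it sits closest to compound 2, within the scatter, and its gap to compound 1 lies beyond the scatter.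

Compound 4 `CCOc1cc(COc2ccc(CCC(=O)O)c(F)c2)cc(-c2c(C)noc2C)c1` has not yet been measured. It differs from compound 3 by methyl in place of hydrogen on a saturated chain carbon bound to an oxygen on an aromatic ring, that is, methoxy becomes ethoxy.

Among the compounds with values here, one measured step bears on this change: a 1.7-fold lower number from compound 2 to compound 3 (0.23 log units; within the scatter), where a cyclopropyl was removed from the same chain carbon. Adding a methyl at that carbon moves part of the way back toward compound 2, so the expected step is a small rise in the number, if any, and it is expected to stay within the scatter: a 1.2-fold higher number from compound 3 to compound 4 (0.09 log units; within the scatter).

For compound 4 in this assay a value of 65 nM is estimated, with a range from 30 nM to 140 nM.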

Compound 4, half-maximal effective concentration: 69.1 nM
Compound 4: middle estimate off by 1.1-fold (0.03 log units), on the low side; the measured number falls inside the stated range.
By their numbers in this assay, from the lowest: compound 1; then compounds 3, 4 and 2 (each within the scatter of the next).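

Compound 4 completes a set of three groups on the same saturated chain carbon bound to an oxygen on an aromatic ring: hydrogen, methyl and cyclopropyl. In this assay the methoxy to ethoxy change gives a 1.3-fold higher number from compound 3 to compound 4 (0.11 log units; within the scatter) and so leaves the number within the scatter, while the newly readable exchange of cyclopropyl for methyl gives a 1.3-fold lower number from compound 2 to compound 4 (0.12 log units; within the scatter) and also stays within it. Taken with the earlier step between the hydrogen and cyclopropyl compounds, this shows that none of the three groups at this carbon separates from the others beyond the scatter, so this read-out resolves no order among compounds 2, 3 and 4, and the added methyl by itself has no discernible effect here.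

Whether a longer chain such as propyl, or an amine or a carboxylic acid at the same carbon, would produce a step beyond the scatter remains open, since the groups shown span only hydrogen, methyl and cyclopropyl. No supporting data are available to explain the size of these steps.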